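The compounds below may be only part of what the source reports. "The series", "measured", "known", "first", "only" and "open" are said of these compounds alone.

Compound 1, `CCCCCCCCC(=O)N1c2ccccc2CCC1C(=O)Nc1ccccc1C(F)(F)F`, gives 7700 nM in a functional assay on HCT-15 cells (Homo sapiens) for cytotoxicity, read by sulforhodamine B assay, with a stated time of 72 h; a higher number here means a weaker inhibitor of growth, a lower number a stronger inhibitor of growth.
Compound 2, `CCC(=O)N1c2ccccc2CCC1C(=O)Nc1ccccc1C(F)(F)F`, gives in this assay only a limit of the assay, > 80000 nM.
Compound 3, `CCCCCCCCC(=O)N1c2ccccc2CCC1C(=O)Nc1cc(C(F)(F)F)cc(C(F)(F)F)c1`, gives 4970 nM in this assay.

Compound 4, `CCC(=O)N1c2ccccc2CCC1C(=O)Nc1cc(C(F)(F)F)cc(C(F)(F)F)c1`, has not yet been measured in this assay. It stands to compound 3 as compound 2 stands to compound 1: the change is hydrogen in place of hexyl on a saturated chain carbon, two bonds along the chain from a carbonyl carbon, and the change from compound 1 to compound 2 is hydrogen in place of hexyl on a saturated chain carbon, two bonds along the chain from a carbonyl carbon, the same change at the same place. How the core of compound 3 differs from the core of compound 1 is not broken down here. Among the measured compounds, compound 3 carries the lowest number, and compound 1 sits within the scatter of it, so the two are not told apart. Going by the values given here, the one measured instance of the change gave an at least 10-fold higher number from compound 1 to compound 2 (1.01 log units; beyond the scatter), where the second value is the limit of > 80000 nM in this assay, at which 1 of the 3 values shown sits, so the full size of that step is not known, only that it is large.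

From compound 3 to compound 4 the same change is expected to give a step of similar size, a 12-fold higher number from compound 3 to compound 4 (1.08 log units; beyond the scatter), resting on the step from compound 1 to compound 2. Compound 4 is therefore estimated at 60000 nM, with the range running from 20000 nM to 160000 nM, and with a real chance that compound 4 likewise reports only a limit in this assay.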

Compound 4, concentration for 50% growth inhibition: 7620 nM
Estimate against measurement, compound 4: 7.9-fold (0.90 log units) above, outside the stated range (below it).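

In this assay, hydrogen in place of hexyl on a saturated chain carbon, two bonds along the chain from a carbonyl carbon, gave a 1.5-fold higher number from compound 3 to compound 4 (0.19 log units; within the scatter), so on this core the change does not separate the two compounds. Set beside the earlier step, the change did not carry over at the same size from one core to the other: the same change on two cores in this assay, an at least 10-fold higher number (1.01 log units; beyond the scatter) from compound 1 to compound 2 and a 1.5-fold higher number (0.19 log units; within the scatter) from compound 3 to compound 4, at least 6.7-fold (0.83 log units) apart, beyond the scatter of two such steps. Going by these compounds alone, with only one pair on each core, this shows that the size of the step cannot be assumed to transfer between these two cores, but it does not show which difference between the cores matters, and the full size of the earlier step remains unknown: the limit of > 80000 nM in this assay, at which 1 of the 4 values shown sits.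

The compounds shown leave open how the numbers run on either core for chains between propanoyl and the octylcarbonyl group, and for a longer chain than the octylcarbonyl group. They also leave open whether the same change would give a large step, a small one or neither on further cores, and how a chain ending in an amine or a carboxylic acid would compare with the plain chains.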